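The compounds below may be only part of what the source reports. "The series", "measured", "known", "first", "only" and "open" are said of these compounds alone.

In a functional assay on MGC-803 cells (Homo sapiens) for inhibition, read by MTT assay, with a stated time of 72 h (a higher number here means a weaker inhibitor, a lower number a stronger inhibitor), compound 1 `CC(C)n1ncc2c(C(=O)Nc3ccccc3)cccc21` gives 38500 nM. Compound 2 `CC(C)n1ncc2c(C(=O)Nc3cccnc3)cccc21` reaches only a limit in this assay, > 40000 nM. For the measured compounds named here, the one measured step, an at least 1.0-fold higher number from compound 1 to compound 2 (0.01 log units; that floor lies within the scatter), lies within the scatter. Compound 3 `CC(C)n1ncc2c(C(=O)NCc3cn(-c4ccc(I)cc4)nn3)cccc21` also reaches only a limit in this assay, > 40000 nM. Compound 3 thus stands at the limit of > 40000 nM in this assay, at which 2 of the 3 values shown sit. Compound 4 `CC(C)n1ncc2c(C(=O)NCc3cn(-c4ccc([N+](=O)[O-])cc4)nn3)cccc21` differs from compound 3 by nitro in place of iodo on an aromatic carbon. Going by the values given here, no measured step touches this part of the structure; the step from compound 1 to compound 2 concerns the amide-type nitrogen instead. Compound 4 is therefore expected to give 50000 nM in this assay, within a range from 20000 nM to 150000 nM. The expected step is a step that the limit leaves unreadable from compound 3 to compound 4, none beyond the scatter, most likely again a limit.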

Compound 4, half-maximal inhibitory concentration: > 40000 nM
Compound 4 ended at the assay's limit; the forecaster's own chance of this, stated with the estimate: 80%; the middle value does not contradict the limit.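

For the compounds shown here, compound 3 and compound 4 both end at a limit in this assay, so no step between them can be read: the limit of > 40000 nM in this assay, at which 3 of the 4 values shown sit. The compounds shown leave open whether 4-iodophenyl and 4-nitrophenyl differ at all in this assay.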